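Methoxy to propoxy on the shared core

This account rests on a few compounds, and the source may have more. Where it says the series, first, only, none or still open, it means among the compounds named here.

- compound 1 `CCCC1=C(OC)C(CCC)(CCC)C(=O)/C(=C(O)\C=C\c2ccccc2)C1=O` gives "not determined" (no result reported)
- compound 2 `CCCC1=C(OC)C(CCC)(CCC)C(=O)/C(=C(O)\C=C\c2ccc(I)cc2)C1=O` gives 1.8 uM

Compound 1 has no single number in a functional assay on MCF7 cells (Homo sapiens) for antiproliferative activity, read by sulforhodamine B assay, with a stated time of 3 days (on this read-out lower numbers stand for an effect already at smaller amounts and higher numbers for an effect only at larger amounts of compound), and its entry stays at "not determined" (no result reported) as a result, so the step has no measured start. Compound 3 `CCCOC1=C(CCC)C(=O)/C(=C(O)/C=C/c2ccccc2)C(=O)C1(CCC)CCC` is still unmeasured. The change is ethyl in place of hydrogen on a saturated chain carbon bound to an oxygen on an unsaturated carbon and reads in words as ethyl in place of hydrogen on a saturated chain carbon bound to an oxygen on an unsaturated carbon. Within the data shown here, no measured step shows its size, so none beyond the scatter is expected in this assay and no direction is assumed. Among the measured compounds shown here, the only number available is compound 2 at 1.8 uM and it anchors the estimate. Compound 3 is expected at 3 uM with an estimated range from 0.8 uM to 12 uM for now.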

Compound 3, concentration for half-maximal effect: 1.6 uM
Compound 3: the middle estimate sits 1.9-fold (0.27 log units) above what was measured, and the stated range covers the measured number.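

In this assay, among these compounds, compound 1 stands at "not determined" (no result reported) so no step to compound 3 can be read. The compounds shown leave open what methoxy to propoxy does on the shared core, and nothing at hand bears on any cause.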